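This account rests on a few compounds, and the source may have more. Where it says the series, first, only, none or still open, it means among the compounds named here.

Working notes on the series.

In a functional assay for inhibition, with Homo sapiens as the target (a higher number here means a weaker inhibitor, a lower number a stronger inhibitor), compound 1 `Oc1nnc(-c2ccccc2)c2cncn12` gives 19000 nM. Compound 3 `CC(C)c1ncn2c(O)nncc12` returns only a limit, > 48000 nM. Compound 2 `CSc1nncc2c(C(C)C)ncn12` likewise returns only a limit, > 48000 nM. The change from compound 3 to compound 2 is methylsulfanyl in place of hydroxy on an aromatic carbon, and its step, a step that the two limits leave unreadable from compound 3 to compound 2, cannot be sized, since (the limit of > 48000 nM in this assay, at which 2 of the 3 values shown sit).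

Compound 4 `CSc1nnc(-c2ccccc2)c2cncn12` carries the same kind of change on the core of compound 1: methylsulfanyl in place of hydroxy on an aromatic carbon. The two places agree except that in compound 4 the site is also para to a group of 6 heavy atoms. How the core of compound 1 differs from that of compound 3 is not broken down here.

Going by the values given here, with the one measured step unreadable, the expectation for compound 4 rests on compound 1 at 19000 nM alone, so a step of a 1.3-fold higher number from compound 1 to compound 4 (0.12 log units; within the scatter) is estimated. Compound 4 is thus expected at about 25000 nM, somewhere between 8000 nM and 80000 nM.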

Compound 4, half-maximal inhibitory concentration: > 48000 nM
Compound 4: a limit, no number (the forecaster's own chance of this, stated with the estimate: 35%); middle value at least 1.9-fold (0.28 log units) away from the limit.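

Methylsulfanyl in place of hydroxy on an aromatic carbon gives an at least 2.5-fold higher number from compound 1 to compound 4 (0.40 log units; beyond the scatter) in this assay, a loss of inhibition on the core of compound 1 whose full size stays open. Going by these compounds alone, the same change on the core of compound 3 cannot be read, so no second sized step stands beside this one, and the notes do not show whether the change carries from one core to the other. Most of the series sits at one limit: the limit of > 48000 nM in this assay, at which 3 of the 4 values shown sit.

From the compounds shown here alone, whether an amine or a methoxy group in place of hydroxy would keep the inhibition seen with compound 1 stays open. So does what a longer chain in place of methylsulfanyl would give on either core.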